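Replacing the Fluorophenyl with a Methoxyphenyl Group

A few compounds are considered here, and "the series" means these few. Any claim that something is new, unique, unknown or untested is made for them only; others in the source may bear on it.

Of the compounds shown here, two have been measured so far. Compound 1 `Cc1nc(-c2ccccc2Cl)sc1COc1ccc2c(c1)OCC2CC(=O)O` gives 12.4% in a functional assay on CHO cells for agonist activity at Free fatty acid receptor 1 (Homo sapiens), read by FLIPR and calcium flux, tested at 100 nM; on this read-out higher numbers stand for a stronger effect at the one concentration tested and lower numbers for a weaker effect. Within the data shown here, compound 2 `Cc1nc(-c2ccccc2F)sc1COc1ccc2c(c1)OCC2CC(=O)O` gives 25.8% in this assay, and the only measured step, a number 13.4 percentage points higher from compound 1 to compound 2 (beyond the scatter), sets it apart. Compound 2 therefore stands highest of the two numbers, with compound 1 the nearest, lower by a margin beyond the scatter.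

Compound 3 `COc1ccc(-c2nc(C)c(COc3ccc4c(c3)OCC4CC(=O)O)s2)cc1` differs from compound 2 by 4-methoxyphenyl in place of 2-fluorophenyl on an aromatic carbon. Among the measured compounds shown here, the single measured step exchanged one halogen for another on the same ring; it does not show what happens when the whole 2-fluorophenyl gives way to 4-methoxyphenyl, so it bears on this step only loosely. With no closer guide, the number for compound 3 is expected to stay near that of compound 2, giving an estimated step of a number 1.8 percentage points lower from compound 2 to compound 3 (within the scatter). Compound 3 is estimated at 24%, within a range from 5% to 50%.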

Compound 3, a percentage reported as activity, at one concentration (the size of the read-out at that concentration, not a potency): 46.8%
Beside the measured number, compound 3's estimate is 22.8 percentage points below it; the measured number falls inside the stated range.
By their numbers in this assay, from the lowest: compound 1; then compound 2; then compound 3.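

At this position, on an aromatic carbon of the five-membered ring, the change goes beyond one halogen for another: 4-methoxyphenyl in place of 2-fluorophenyl gives a number 21 percentage points higher from compound 2 to compound 3 (beyond the scatter) in this assay. Set against 2-chlorophenyl, the same group gives a number 34.4 percentage points higher from compound 1 to compound 3 (beyond the scatter), the largest step among these compounds, so this position can take a different aryl group without losing the effect at the one concentration tested. Nothing available here explains why the number rises.

The step changes both the group on the phenyl ring and where it sits on that ring, so the compounds shown leave open which of these two changes matters. Also open, as far as these compounds go, is whether an amine or a longer chain, such as ethoxy, on that phenyl ring would raise or lower the number.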